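A few compounds are considered here, and "the series" means these few. Any claim that something is new, unique, unknown or untested is made for them only; others in the source may bear on it.

In a functional assay on SGC-7901 cells (Homo sapiens) for antiproliferative activity, read by MTT assay, with a stated time of 72 h (a higher number here means a weaker inhibitor, a lower number a stronger inhibitor), three compounds built on one shared core have been measured. Compound 1 (`CCOC(=O)c1cc(-c2cc(OC)c(OC)c(OC)c2)c(-c2cccc(Br)c2)s1`) gives > 100000 nM, which is a limit of the assay. Compound 2 (`CCOC(=O)c1cc(-c2cc(OC)c(OC)c(OC)c2)c(-c2ccc(OC)c([N+](=O)[O-])c2)s1`) gives a true number, 18100 nM. Compound 3 (`CCOC(=O)c1cc(-c2cc(OC)c(OC)c(OC)c2)c(-c2ccc(OC)c(OCc3ccccc3)c2)s1`) gives > 100000 nM, again only a limit. Compound 3 thus stands at the limit of > 100000 nM in this assay, at which 2 of the 3 values shown sit.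

The next compound, compound 4 (`CCOC(=O)c1cc(-c2cc(OC)c(OC)c(OC)c2)c(-c2ccc(OC)c(O)c2)s1`), has not been measured. It differs from compound 3 as follows: hydrogen in place of benzyl on an oxygen on an aromatic ring. In short, benzyloxy becomes hydroxy.

Among the compounds with values here, two measured steps bear on this change. The closer one is an at least 5.5-fold higher number from compound 2 to compound 3 (0.74 log units; beyond the scatter), where benzyloxy took the place of nitro. The other is an at least 5.5-fold lower number from compound 1 to compound 2 (0.74 log units; beyond the scatter), where 4-methoxy-3-nitrophenyl replaced 3-bromophenyl. Within the data shown here, both lie beyond the scatter, but each is bounded from one side only, and no compound with a hydroxy group has been measured yet. Losing the benzyl is therefore expected to give a lower number, by a step at least as large as these, with wide uncertainty. The expected step is an at least 20-fold lower number from compound 3 to compound 4 (1.30 log units; beyond the scatter). For compound 4 the estimated value is 5000 nM, with an expected range from 300 nM to 60000 nM.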

Compound 4, half-maximal inhibitory concentration: 1580 nM
Beside the measured number, compound 4's estimate is 3.2-fold (0.50 log units) above it; measured number inside the range.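

In this assay, hydrogen in place of benzyl on the oxygen gives an at least 63-fold lower number from compound 3 to compound 4 (1.80 log units; beyond the scatter), so this place on the aromatic ring can carry a measurable gain once benzyloxy becomes hydroxy. Hydroxy in place of nitro gives an 11-fold lower number from compound 2 to compound 4 (1.06 log units; beyond the scatter), the one new step between two true numbers, which makes compound 4 the strongest of the four compounds shown. 3-Hydroxy-4-methoxyphenyl in place of 3-bromophenyl gives an at least 63-fold lower number from compound 1 to compound 4 (1.80 log units; beyond the scatter), and this step, like the one from compound 3, starts from a limit of the assay rather than a number: the limit of > 100000 nM in this assay, at which 2 of the 4 values shown sit.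

The compounds shown leave open how an amine or a methoxy group at this place would compare with hydroxy. They also leave open whether a carboxylic acid or an amide could stand in for the ethyl ester while the hydroxy stays.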